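This account rests on a few compounds, and the source may have more. Where it says the series, first, only, none or still open, it means among the compounds named here.

Measured compounds in a functional assay (aorta) with Rattus norvegicus as the target; a higher number here means a more potent compound, by a factor of ten per unit of this negative logarithm, a lower number a less potent compound:

compound 1, `CC1(C)C=C(n2ccccc2=O)c2cc(C=O)ccc2O1`, compound 1 gives 6.91
compound 2, `CC1(C)C=C(n2ccccc2=O)c2cc(OCC(=O)c3ccccc3)ccc2O1`, compound 2 gives 5.05

Compound 2 stands lowest of the two numbers; its nearest neighbour is compound 1, whose value lies beyond the usual scatter above it. Going by the values given here, no pair differing in one place has been measured, so nothing here shows how a single change moves this assay.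

Compound 3, `CC1(C)C=C(n2ccccc2=O)c2cc(OS(=O)(=O)F)ccc2O1`, is the next compound to be measured. Its difference from compound 2: fluorosulfonyl in place of benzoylmethyl on an oxygen on an aromatic ring. The group that leaves carries one six-membered aromatic ring of carbon only and one hydrogen-bond acceptor; the fluorosulfonyl that enters carries no ring and two hydrogen-bond acceptors.

Without a measured step the size of the change in this assay is uncertain. The expectation is an upward step of moderate size, a number 0.95 log units higher from compound 2 to compound 3 (beyond the scatter), because compound 1 with its smaller substituent at that position reaches 6.91 while compound 2 sits at 5.05. For compound 3 the estimate is 6, expected to fall between 5.3 and 6.7.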

Compound 3, logarithm of the reciprocal of the active concentration, log(1/C): 7.95
The estimate for compound 3 lay 1.95 log units below the measured number; measured number outside the range, above it.
By their numbers in this assay, from the lowest: compound 2; then compound 1; then compound 3.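

In this assay the exchange of benzoylmethyl for fluorosulfonyl on the oxygen on an aromatic ring gives a number 2.90 log units higher from compound 2 to compound 3 (beyond the scatter) and shows that this position responds strongly to what the oxygen carries. Compared on the same aromatic carbon, (fluorosulfonyl)oxy also outdoes formyl, with a number 1.04 log units higher from compound 1 to compound 3 (beyond the scatter) and this makes compound 3 the most potent of the three, so a formyl group does not mark the upper end at this position. Nothing measured on these compounds accounts for the size of either step.

The compounds shown leave open whether the gain belongs to the fluorosulfonyl itself or follows from losing the six-membered aromatic ring of benzoylmethyl. A methylsulfonyl or a plain methyl on the same oxygen, or a nitrile or an amine on the same aromatic carbon, would help to separate these readings.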